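The compounds below may be only part of what the source reports. "The series", "measured", "known", "first", "only" and "open" are said of these compounds alone.

Measured compounds:
compound 1, `COc1ccc(-c2cnc3nc(N)nc(N4CCN(C(=O)c5ccccc5)CC4)c3n2)cc1OC`, 400 nM
compound 2, `COc1ccc(-c2cnc3nc(N)nc(N4CCN(c5cc(Cl)cc(Cl)c5)CC4)c3n2)cc1OC`, 3400 nM
compound 3, `COc1ccc(-c2cnc3nc(N)nc(N4CCN(c5ccc(F)cc5)CC4)c3n2)cc1OC`, 100 nM

In a functional assay on cells (T-cell, Homo sapiens) for inhibition (on this read-out lower numbers stand for stronger inhibition and higher numbers for weaker inhibition), compound 3 gives the lowest number of the three, with compound 1 nearest at a 4.0-fold lower number from compound 1 to compound 3 (0.60 log units; beyond the scatter) and compound 2 furthest at a 34-fold lower number from compound 2 to compound 3 (1.53 log units; beyond the scatter). Compound 4 is `COc1ccc(-c2cnc3nc(N)nc(N4CCN(Cc5ccccc5F)CC4)c3n2)cc1OC`; relative to compound 3 it shows (2-fluorobenzyl in place of 4-fluorophenyl on an amine nitrogen in a ring). For the measured compounds named here, no measured pair compares a benzyl with a directly attached aryl on the ring nitrogen, so the bearing of the known steps is indirect. The step of an 8.5-fold higher number from compound 1 to compound 2 (0.93 log units; beyond the scatter) and the step of a 4.0-fold lower number from compound 1 to compound 3 (0.60 log units; beyond the scatter) together show that the group on this nitrogen moves the read-out by modest to large amounts, and the step of a 34-fold lower number from compound 2 to compound 3 (1.53 log units; beyond the scatter) shows that both the halogen pattern and the ring attachment matter. Because a 4.0-fold lower number from compound 1 to compound 3 (0.60 log units; beyond the scatter) places the directly bonded 4-fluorophenyl below the benzoyl linker, a change away from that group is expected to raise the number somewhat. Compound 4 is therefore estimated at 300 nM, in a range of 80 nM to 1200 nM, which is expected as a 3.0-fold higher number from compound 3 to compound 4 (0.48 log units; beyond the scatter).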

Compound 4, half-maximal inhibitory concentration: 700 nM
Estimate against measurement, compound 4: 2.3-fold (0.37 log units) below; measured number inside the range.
By their numbers in this assay, from the lowest: compound 3; then compounds 1 and 4 (each within the scatter of the next); then compound 2.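

In this assay, moving from the directly attached 4-fluorophenyl to 2-fluorobenzyl on the ring nitrogen gives a 7.0-fold higher number from compound 3 to compound 4 (0.85 log units; beyond the scatter), so the 4-fluorophenyl group keeps the lowest number of the four. The 2-fluorobenzyl group still reads well clear of 3,5-dichlorophenyl, with a 4.9-fold lower number from compound 2 to compound 4 (0.69 log units; beyond the scatter), while the step of a 1.8-fold higher number from compound 1 to compound 4 (0.24 log units; within the scatter) leaves it and benzoyl with no order between them. Nothing available accounts for these differences.

The change alters both the attachment of the ring and the placing of the fluorine, and the compounds shown do not separate the two, which a 4-fluorobenzyl group on the same nitrogen could do. Going by these compounds, how a pyridine ring or a longer chain would read at this position also stays open.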